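A few compounds are considered here, and "the series" means these few. Any claim that something is new, unique, unknown or untested is made for them only; others in the source may bear on it.

In a functional assay on HUVEC cells (Homo sapiens) for inhibition, with a stated time of 4 days (on this read-out higher numbers stand for weaker inhibition and lower numbers for stronger inhibition), compound 1 (`COc1ccc(C(N)=O)cc1/C=C/c1ccc(C(C)(C)C)cc1`) gives 370 nM, compound 2 (`COc1ccc(C(N)=O)cc1/C=C/c1ccc(C(F)(F)F)cc1`) gives 880 nM and compound 3 (`COc1ccc(C(N)=O)cc1/C=C/c1ccc(F)cc1`) gives 2100 nM, the highest number of the three and so the weakest inhibition. Compound 4 (`COc1ccc(C(N)=O)cc1/C=C/c1ccc([N+](=O)[O-])cc1`) has nitro in place of fluoro on an aromatic carbon. Going by the values given here, two measured steps bear on this change: a 2.4-fold higher number from compound 2 to compound 3 (0.38 log units; beyond the scatter), and a 5.7-fold higher number from compound 1 to compound 3 (0.75 log units; beyond the scatter). Both are modest and end at fluoro, so read backwards, each replacement of fluoro lowers the number, although neither involves nitro. A modest fall in this assay is therefore expected, close to the smaller step. The expected change is a 2.1-fold lower number from compound 3 to compound 4 (0.32 log units; beyond the scatter). Compound 4 is estimated at 1000 nM, with an expected range of 350 nM to 2800 nM.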

Compound 4, half-maximal inhibitory concentration: 4700 nM
The estimate for compound 4 lay 4.7-fold (0.67 log units) below the measured number, outside the stated range (above it).
By their numbers in this assay, from the lowest: compound 1; then compound 2; then compound 3; then compound 4.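

Replacing fluoro with nitro gives a 2.2-fold higher number from compound 3 to compound 4 (0.35 log units; beyond the scatter) in this assay and so reverses the direction seen with tert-butyl and trifluoromethyl, which both give lower numbers than fluoro. Compound 4 is the weakest inhibitor of the four, with a 5.3-fold higher number from compound 2 to compound 4 (0.73 log units; beyond the scatter) and the large 13-fold higher number from compound 1 to compound 4 (1.10 log units; beyond the scatter), so the choice of group at this position, para to a large group, moves the number widely. Nothing measured here explains this reversal. From the compounds shown here alone, it remains open where an amine or a carboxylic acid on this aromatic carbon would fall in this order. Going by these compounds, whether a longer chain would give a lower number than tert-butyl is also open.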